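Amino in Place of Nitro on Two Different Cores

The source may hold more compounds than are shown below. What is called first, only, known or untested is meant among the compounds shown, and "the series" means these compounds.

The measured compounds and their values:
Compound 1, `COc1ccc(-n2ccnc2-c2cc(OC)c(OC)c(OC)c2)cc1[N+](=O)[O-]`, in a functional assay on HT-29 cells (Homo sapiens) for antiproliferative activity, read by MTT assay, with a stated time of 72 h (a lower number here means a stronger inhibitor, a higher number a weaker inhibitor), compound 1 gives 600 nM.
Compound 2, `COc1ccc(-n2ccnc2-c2cc(OC)c(OC)c(OC)c2)cc1N`, in this assay compound 2 gives 200 nM.
Compound 3, `COc1ccc(NC(=O)c2cc(OC)c(OC)c(OC)c2)cc1[N+](=O)[O-]`, in this assay compound 3 gives 9700 nM.

Compound 1 and compound 2 share one core and differ in a single place: amino in place of nitro on an aromatic carbon. This change brought a 3.0-fold lower number from compound 1 to compound 2 (0.48 log units; beyond the scatter), a clear but modest gain.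

Compound 3 is built on a different core; how the two cores differ is not broken down here. Its value sits far above those of compound 1 and compound 2, so compound 3 is the weakest inhibitor of the three measured in this assay.

Compound 4, `COc1ccc(NC(=O)c2cc(OC)c(OC)c(OC)c2)cc1N`, has not yet been measured. It arises from compound 3 by the same change that turns compound 1 into compound 2: amino in place of nitro on an aromatic carbon. The surroundings of the place are the same in both pairs, so this is the same change, not merely a similar one. For the measured compounds named here, the only guide for what to expect is that single earlier step, and because it gave a 3.0-fold lower number from compound 1 to compound 2 (0.48 log units; beyond the scatter), a step of about the same size is expected here: a 3.0-fold lower number from compound 3 to compound 4 (0.48 log units; beyond the scatter). With just one prior example on a different core, the uncertainty is wide. On that basis, compound 4 is estimated to give 3200 nM in this assay, most likely between 1200 nM and 8500 nM.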

Compound 4, half-maximal inhibitory concentration: 1200 nM
Beside the measured number, compound 4's estimate is 2.7-fold (0.43 log units) above it, within the range that was stated.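

On both cores the change points the same way, since in this assay amino in place of nitro also gives an 8.1-fold lower number from compound 3 to compound 4 (0.91 log units; beyond the scatter). So the direction carried over from one core to the other, but the size of the step did not stay the same: the same change on two cores in this assay, a 3.0-fold lower number (0.48 log units; beyond the scatter) from compound 1 to compound 2 and an 8.1-fold lower number (0.91 log units; beyond the scatter) from compound 3 to compound 4, 2.7-fold (0.43 log units) apart, beyond the scatter of two such steps. This shows that the core around the change can matter to how much is gained, yet two pairs cannot give a rule for a further core, and these numbers alone do not tell what about the two cores sets the steps apart.

The compounds shown leave open whether another group at the same place, such as a hydroxyl or a nitrile, would rank the same way on both cores, or whether amino is special in this respect. They also leave open whether the step would keep its size if the methoxy group that the place lies ortho to gave way to a longer chain such as ethoxy.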